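The source may hold more compounds than are shown below. What is called first, only, known or untested is meant among the compounds shown, and "the series" means these compounds.

Measured compounds:
Compound 1, `C[Se]/C(=N\C(=O)c1ccco1)NC(=O)c1ccco1`, in a functional assay on K562 cells (Homo sapiens) for cytotoxicity, read by MTT assay, with a stated time of 72 h (on this read-out lower numbers stand for stronger inhibition of growth and higher numbers for weaker inhibition of growth), gives 8780 nM.
Compound 2, `CS/C(=N\C(=O)c1ccco1)NC(=O)c1ccco1`, in this assay gives 64800 nM.
Compound 3, `CS/C(=N\C(=O)c1cc(-c2ccccc2)nc2ccccc12)NC(=O)c1cc(-c2ccccc2)nc2ccccc12`, in this assay gives 34400 nM.

Compound 4, `C[Se]/C(=N\C(=O)c1cc(-c2ccccc2)nc2ccccc12)NC(=O)c1cc(-c2ccccc2)nc2ccccc12`, has not yet been measured in this assay.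

Compounds 1 and 2 share one core; compounds 3 and 4 share another. How the two cores differ is not broken down here, and the values of compound 2 and compound 3 lie within the usual scatter of each other, so nothing can be said about an order between them. Compound 1 sits beyond the scatter from compound 3 and gives the lowest of the three numbers.

Within the first core, one change is measured: a group of 2 heavy atoms (1 carbon, 1 selenium; no ring) in place of a group of 2 heavy atoms (1 carbon, 1 sulfur; no ring), on a carbon with a double bond to nitrogen. It gave a 7.4-fold lower number from compound 2 to compound 1 (0.87 log units; beyond the scatter). The step from compound 3 to compound 4 is the same change, at the same place: a group of 2 heavy atoms (1 carbon, 1 selenium; no ring) in place of a group of 2 heavy atoms (1 carbon, 1 sulfur; no ring), on a carbon with a double bond to nitrogen.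

For the measured compounds named here, since the second core has no measured pair of its own, the only guide for compound 4 is compound 1 against compound 2. Compound 4 is therefore expected to show a step of about a 6.3-fold lower number from compound 3 to compound 4 (0.80 log units; beyond the scatter), because the measured step of a 7.4-fold lower number from compound 2 to compound 1 (0.87 log units; beyond the scatter) on the other core was of that size, though a single example leaves the transfer uncertain. The estimate for compound 4 in this assay is 5500 nM, expected to lie between 2000 nM and 15000 nM.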

Compound 4, concentration for 50% growth inhibition: 5800 nM
The estimate for compound 4 lay 1.1-fold (0.02 log units) below the measured number; the measured number falls inside the stated range.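

In this assay, putting the selenium group in place of methylsulfanyl, on a carbon with a double bond to nitrogen whose other neighbours are two amide-type nitrogens, gave a 5.9-fold lower number from compound 3 to compound 4 (0.77 log units; beyond the scatter), and this step agrees in size with the one measured on the other core: the same change on two cores in this assay, a 7.4-fold lower number (0.87 log units; beyond the scatter) from compound 2 to compound 1 and a 5.9-fold lower number (0.77 log units; beyond the scatter) from compound 3 to compound 4, 1.2-fold (0.09 log units) apart, within the scatter of two such steps Across these two pairs, then, the change carried over from one core to the other, and the step on one core was a fair guide to the step on the other. For the compounds shown here, this does not show that the change would transfer to any further core, since two pairs cover only two cores, and the numbers alone do not explain why the selenium compounds give the lower numbers.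

On these data alone, all four compounds carry either methylsulfanyl or its selenium counterpart at this place, so it remains open whether a longer chain on the sulfur or the selenium, or an amine on that same carbon, would give a similar number. Growth inhibition is also shown in K562 cells alone, which leaves open whether the step would be of similar size in other cells, including non-cancerous ones.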